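The source may hold more compounds than are shown below. What is called first, only, known or untested is meant among the compounds shown, and "the series" means these compounds.

Two compounds have been measured in an assay on cells for displacement of a labelled ligand from Orexin/Hypocretin receptor type 1 (Homo sapiens), read by scintillation counting, with stated times of 10 min and 90 min, tested at 10 uM; on this read-out lower numbers stand for less inhibition and higher numbers for more inhibition at the one concentration tested (going by the name of the read-out):

- Compound 1 `COC(=O)c1cccc2c(C(=O)c3ccccc3)cc(C(=O)c3ccc(C(F)(F)F)cc3)c-2c1` gives 10.4%
- Compound 2 `COC(=O)c1cccc2c(C(=O)c3ccccc3)cc(C(=O)c3ccc(C(Cl)(Cl)Cl)cc3)c-2c1` gives 10.4%

Compound 1 stands level with compound 2: the step of no change at the digits printed from compound 1 to compound 2 (within the scatter) shows no change, so the two compounds give level numbers in this assay.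

Compound 3 `O=C(O)c1cccc2c(C(=O)c3ccccc3)cc(C(=O)c3ccc(C(F)(F)F)cc3)c-2c1` is the unmeasured compound. It differs from compound 1 by hydrogen in place of methyl on an oxygen next to a carbonyl group, that is, the methoxycarbonyl of compound 1 becomes a carboxy group. Within the data shown here, the single measured step, from compound 1 to compound 2, changes a group on the other end of the molecule, trichloromethyl in place of trifluoromethyl, and so does not touch the ester at all. Among the measured compounds shown here, no measured step bears on the change from an ester to an acid, and the expectation therefore rests only on the low level of compound 1 itself.

With compound 1 already giving little inhibition, the expected step of a number 1.4 percentage points lower from compound 1 to compound 3 (within the scatter) is none beyond the scatter. Compound 3 is estimated at 9%, with a range from -5% to 25%.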

Compound 3, a percentage reported as inhibition, at one concentration (the size of the read-out at that concentration, not a potency): 18.3%
Compound 3: middle estimate off by 9.3 percentage points, on the low side, within the range that was stated.
By their numbers in this assay, from the lowest: compounds 1, 2 and 3 (each within the scatter of the next).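

Among these compounds, the ester end of the molecule is tested here for the first time, since the earlier pair differed only at the far end, in trichloromethyl and trifluoromethyl. In this assay, hydrogen in place of methyl on an oxygen next to a carbonyl group, which turns methoxycarbonyl into carboxy, gives a number 7.9 percentage points higher from compound 1 to compound 3 (within the scatter). The printed difference therefore cannot be separated from ordinary repeat variation, so this exchange, although it replaces an ester with a carboxy group, has no demonstrated effect on the read-out at the single concentration tested. No measurement at hand offers an explanation for this result.

The compounds shown leave open whether other groups in place of methoxycarbonyl, such as a primary amide, a nitrile or a longer ethyl ester, would move the reading beyond the scatter. They also leave open how carboxy would read when paired with trichloromethyl on the far ring, and, with only one concentration reported, how compound 1 and compound 3 would compare as full measures of potency.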